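A few compounds are considered here, and "the series" means these few. Any claim that something is new, unique, unknown or untested is made for them only; others in the source may bear on it.

In a functional assay on AGS cells (Homo sapiens) for inhibition, read by MTT assay, with a stated time of 72 h (a higher number here means a weaker inhibitor, a lower number a stronger inhibitor), compound 1 `Cc1ccc(N2CCCC2)c(C(=O)Nc2ccc(CNC(=O)OCc3cccnc3)cc2)c1` gives 24700 nM. Compound 2 `O=C(NCc1ccc(NC(=O)c2cc(Cl)ccc2N2CCCC2)cc1)OCc1cccnc1` has no exact number, only a limit of > 100000 nM; this is the limit of > 100000 nM in this assay, at which 1 of the 2 values shown sits. Compound 3 `O=C(NCc1ccc(NC(=O)c2cc(Br)ccc2N2CCCC2)cc1)OCc1cccnc1` differs from compound 2 by bromo in place of chloro on an aromatic carbon. Among the measured compounds shown here, the one measured step that bears on this change is an at least 4.0-fold higher number from compound 1 to compound 2 (0.60 log units; beyond the scatter), which exchanges methyl for chloro on that aromatic carbon. Bromo has not yet been measured there, so no step beyond the scatter is expected, and the estimated change is a number no higher from compound 2 to compound 3 (the limit leaves the size open). For compound 3 the expected value is 100000 nM, within an estimated range of 40000 nM to 200000 nM.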

Compound 3, half-maximal inhibitory concentration: > 100000 nM
Compound 3: no number, only a limit; the forecaster's own chance of this, stated with the estimate: 65%; the middle value lies on the limit itself.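

In this assay compound 3 gives > 100000 nM, which is a limit and not a number. Bromo in place of methyl, on the carbon para to a pyrrolidin-1-yl group, gives an at least 4.0-fold higher number from compound 1 to compound 3 (0.60 log units; beyond the scatter), so a second halogen there goes with the weakening first seen with chloro in compound 2. The step between compound 2 and compound 3 cannot be read because both stand at the limit: the limit of > 100000 nM in this assay, at which 2 of the 3 values shown sit.

Going by these compounds, how chloro and bromo rank therefore stays open. Also open, on these data alone, is whether a methoxy group or an amine on this carbon would give a measurable number, as methyl does in compound 1.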